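This account rests on a few compounds, and the source may have more. Where it says the series, first, only, none or still open, it means among the compounds named here.

Compound 3 `COc1cc(-c2ccc(C#N)cc2)ccc1Nc1ccnc(Nc2ccc(C#N)cc2)n1` is one of three compounds tested in a functional assay on MT4 cells (Homo sapiens) for cytotoxicity, read by MTT assay, with a stated time of 5 days; on this read-out higher numbers stand for lower toxicity in this test and lower numbers for higher toxicity in this test. In this assay compound 3 gives > 298000 nM, which is a limit of the assay rather than a number. Compound 2 `COc1cc(Oc2ccnc(Nc3ccc(C#N)cc3)n2)ccc1-c1ccc(C#N)cc1` likewise gives only a limit, > 298000 nM, in this assay. Compound 1 `N#Cc1ccc(Nc2nccc(Nc3ccc(-c4ccc(C#N)cc4)cc3F)n2)cc1` gives 308000 nM in this assay. The one step that joins two of these compounds by a single change, a step that the limit leaves unreadable from compound 1 to compound 3, cannot be read in size because the limit of > 298000 nM in this assay, at which 2 of the 3 values shown sit, sits on compound 3. Compound 3 therefore stands at the limit of this assay, and compound 1 stands close to it.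

Compound 4 `Cc1cc(-c2ccc(C#N)cc2)ccc1Nc1ccnc(Nc2ccc(C#N)cc2)n1` differs from compound 3 by methyl in place of methoxy on an aromatic carbon. No measured step follows this change, and the only step shown, a step that the limit leaves unreadable from compound 1 to compound 3, is unreadable. This account therefore expects no shift beyond the scatter, the step being estimated as a step that the limit leaves unreadable from compound 3 to compound 4. Compound 4 is expected to give about 300000 nM in this assay, within a range from 150000 nM to 600000 nM, most likely reported again as a limit.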

Compound 4, half-maximal cytotoxic concentration: 9200 nM
Beside the measured number, compound 4's estimate is 33-fold (1.51 log units) above it; measured number outside the range, below it.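

In this assay, the place ortho to a large group now proves sensitive to what sits on it: methyl in place of methoxy gives an at least 32-fold lower number from compound 3 to compound 4 (1.51 log units; beyond the scatter), and methyl in place of fluoro gives a 33-fold lower number from compound 1 to compound 4 (1.52 log units; beyond the scatter). The earlier compounds shown here showed no readable change at this place, whereas methyl brings a large one towards higher toxicity in this test. The first of these steps gives only a bound on its size, since it starts from a limit of the assay: the limit of > 298000 nM in this assay, at which 2 of the 4 values shown sit.

The step between fluoro and methoxy still cannot be read. Whether the drop is particular to methyl or would also follow with an ethyl group, a chlorine atom or an amine at this place stays open, as does the reason for it.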